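Cytotoxicity on Huh-7 cells: chlorophenyl regiochemistry on the pyrazole nitrogen

A few compounds are considered here, and "the series" means these few. Any claim that something is new, unique, unknown or untested is made for them only; others in the source may bear on it.

Two members of the series have been measured in an ADME assay on Huh-7 cells (Homo sapiens) for cytotoxicity; a higher number here means that more compound is tolerated, a lower number that less compound is tolerated. Compound 1 `Cc1ccccc1-c1nn(-c2ccc(Cl)cc2)cc1CNCCN1CCN(C)CC1` gives 17000 nM in this assay. Compound 2 `CN1CCN(CCNCc2cn(-c3ccc(F)cc3F)nc2-c2cccc(Cl)c2)CC1` gives 15000 nM in this assay. The two numbers lie within the usual scatter of each other, so compound 1 does not stand apart from compound 2 on what has been measured; the two compounds differ in several places at once, so no single step can be read from them.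

Compound 3 `Cc1ccccc1-c1nn(-c2cccc(Cl)c2)cc1CNCCN1CCN(C)CC1` has not yet been measured in this assay. It differs from compound 1 in one place: 3-chlorophenyl in place of 4-chlorophenyl on an aromatic nitrogen. Going by the values given here, with no measured pair showing this change, the expectation rests on the fact that the two measured compounds, which differ more widely, still sit within the scatter of each other. The step from compound 1 to compound 3 is therefore expected to be a 1.1-fold lower number from compound 1 to compound 3 (0.05 log units; within the scatter) in this assay, that is, no change beyond the scatter in either direction. Compound 3 is estimated at 15000 nM in this assay, with a range from 7000 nM to 35000 nM.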

Compound 3, half-maximal cytotoxic concentration: 16000 nM
Compound 3: middle estimate off by 1.1-fold (0.03 log units), on the low side; the measured number falls inside the stated range.
By their numbers in this assay, from the lowest: compounds 2, 3 and 1 (each within the scatter of the next).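

In this assay the pair of compound 1 and compound 3 is the one comparison among the compounds shown that differs in a single place: 3-chlorophenyl in place of 4-chlorophenyl on the aromatic nitrogen gives a 1.1-fold lower number from compound 1 to compound 3 (0.03 log units; within the scatter) and so, on this core, the two chlorine placements cannot be told apart. Compound 1 and compound 2 differ in several places at once, whereas here the two compounds have the same atoms and the 2-methylphenyl group and the large group on the five-membered ring stay fixed, which confines the reading to this one position. Nothing available on these compounds accounts for this result.

The reading covers only these two chlorophenyl groups on a single core, so it does not say whether 2-chlorophenyl, or a phenyl bearing an amine or a carboxylic acid in place of the chlorine, would stay within the scatter of compound 1. It also leaves open whether the same swap would read alike with the 3-chlorophenyl carbon substituent that compound 2 carries on the five-membered ring.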